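The compounds below may be only part of what the source reports. "The series", "measured", "known", "first", "only" and "open" are said of these compounds alone.

Measured so far:
compound 1 `COc1ccc(C)cc1N1C(=O)CSC1c1cccc(C(=O)NCCCCc2ccccc2)c1` with 95%
compound 2 `O=C(NCCCCc1ccccc1)c1cccc(C2SCC(=O)N2c2cccc(F)c2)c1` with 94%
compound 3 `COc1c(F)cccc1N1C(=O)CSC1c1cccc(C(=O)NCCCCc2ccccc2)c1` with 12%

In a functional assay on HOS-TE85 cells (Homo sapiens) for inhibition, read by CCK-8 assay, with a stated time of 72 h, tested at 1 uM (a higher number here means more inhibition at the concentration tested (going by the name of the read-out), a lower number less inhibition), compound 3 stands lowest of the three, a number 83 percentage points lower from compound 1 to compound 3 (beyond the scatter) and a number 82 percentage points lower from compound 2 to compound 3 (beyond the scatter), while a number 1 percentage points lower from compound 1 to compound 2 (within the scatter). Compound 4 `COc1ccc(F)cc1N1C(=O)CSC1c1cccc(C(=O)NCCCCc2ccccc2)c1` is not yet measured. It differs from compound 3 by 5-fluoro-2-methoxyphenyl in place of 3-fluoro-2-methoxyphenyl on an amide-type nitrogen in a ring. The two large steps, a number 83 percentage points lower from compound 1 to compound 3 (beyond the scatter) and a number 82 percentage points lower from compound 2 to compound 3 (beyond the scatter), are the ones that bear on this change, since both lead into the 3-fluoro-2-methoxyphenyl group that now leaves. The entering 5-fluoro-2-methoxyphenyl group differs from the 2-methoxy-5-methylphenyl group of compound 1 only in fluorine in place of methyl, and compound 1 gives 95%. Compound 4 is therefore expected to recover much of the inhibition, a step of a number 63 percentage points higher from compound 3 to compound 4 (beyond the scatter), giving an estimated 75% within the range 35% to 96%.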

Compound 4, a percentage reported as inhibition, at one concentration (the size of the read-out at that concentration, not a potency): 95%
The estimate for compound 4 lay 20 percentage points below the measured number; the measured number falls inside the stated range.
By their numbers in this assay, from the lowest: compound 3; then compounds 2, 1 and 4 (each within the scatter of the next).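

In this assay, the same atoms joined differently give a number 83 percentage points higher from compound 3 to compound 4 (beyond the scatter) and so the low number of compound 3 belongs to the 3-fluoro-2-methoxyphenyl group, not to methoxy or fluoro as such. The methoxy change that was costly in compound 3 here gives a number 1 percentage points higher from compound 2 to compound 4 (within the scatter) and fluoro in place of methyl gives no change at the digits printed from compound 1 to compound 4 (within the scatter) as well. Nothing measured here explains this difference between the two fluorine placements.

Going by these compounds, whether chloro or methyl in place of the fluorine of 3-fluoro-2-methoxyphenyl also gives a low number remains open. So does whether ethoxy in place of methoxy in 5-fluoro-2-methoxyphenyl keeps the high one.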